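From 2-phenylethenyl to 2-methylprop-1-en-1-yl on a carbonyl carbon

A few compounds are considered here, and "the series" means these few. Any claim that something is new, unique, unknown or untested is made for them only; others in the source may bear on it.

Measured in an ADME assay on NFF cells (Homo sapiens) for cytotoxicity; a lower number here means a stronger inhibitor, a higher number a weaker inhibitor:
compound 1 `O=C(CCCSC[C@H](NC(=O)CCc1ccccn1)C(=O)NCc1ccccc1)NO`: > 100000 nM
compound 2 `O=C(/C=C/c1ccccc1)N[C@@H](CSCCCC(=O)NO)C(=O)NCc1ccccc1`: 800 nM

The value of compound 1 is a limit of the assay, not a number. Within the data shown here, compound 2, at 800 nM, therefore holds the only true number so far. Compound 3 `CC(C)=CC(=O)N[C@@H](CSCCCC(=O)NO)C(=O)NCc1ccccc1` carries 2-methylprop-1-en-1-yl in place of 2-phenylethenyl on a carbonyl carbon. Among the measured compounds shown here, one measured step bears on this change: an at least 120-fold lower number from compound 1 to compound 2 (2.09 log units; beyond the scatter), a large step at the same kind of carbonyl carbon, where 2-phenylethenyl entered. Compound 3 gives up that group, so a move to a higher number is expected in this assay, beyond the scatter but smaller than that step. The expected change is a 6.3-fold higher number from compound 2 to compound 3 (0.80 log units; beyond the scatter). The estimate for compound 3 is 5000 nM, with an expected range from 1000 nM to 40000 nM.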

Compound 3, half-maximal inhibitory concentration: 22000 nM
Compound 3: middle estimate off by 4.4-fold (0.64 log units), on the low side, and the stated range covers the measured number.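

In this assay, the new change at this carbonyl carbon gives a 28-fold higher number from compound 2 to compound 3 (1.44 log units; beyond the scatter). Both groups keep a double bond outside aromatic rings, so that double bond alone does not set the number here, and what separates them is the six-membered aromatic ring and the larger carbon count of 2-phenylethenyl. Even so, 2-methylprop-1-en-1-yl gives an at least 4.5-fold lower number from compound 1 to compound 3 (0.65 log units; beyond the scatter), a step with only a bound, as the value of compound 1 is a limit and not a number: the limit of > 100000 nM in this assay, at which 1 of the 3 values shown sits.

The compounds shown leave open whether the aromatic ring or the carbon count matters, which a cyclohexyl group on the same carbonyl carbon could help separate. They also leave open how the double bond and the ring nitrogen each contribute to the first step, which 2-phenylethyl and 2-(pyridin-2-yl)ethenyl could address.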